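The source may hold more compounds than are shown below. What is called first, only, known or untested is meant among the compounds shown, and "the series" means these compounds.

Measured in a functional assay (blood) for inhibition, with Homo sapiens as the target; on this read-out higher numbers stand for weaker inhibition and lower numbers for stronger inhibition:

Compound 1 `CC(C)(C)Sc1c(CC(C)(C)C(=O)O)n(Cc2ccc(Cl)cc2)c2ccc(OCc3ccc4cc(F)c(F)cc4n3)cc12`: > 3000 nM, a limit of the assay.
Compound 2 `CC(C)(C)Sc1c(CC(C)(C)C(=O)O)n(Cc2ccc(Cl)cc2)c2ccc(OCc3ccc4cccnc4n3)cc12`: > 3000 nM, a limit of the assay.

Compound 2 has no number on this read-out, only the limit > 3000 nM. Compound 3 `CC(C)(C)Sc1c(CC(C)(C)C(=O)O)n(Cc2ccc(Cl)cc2)c2ccc(OCc3nc4ccccc4o3)cc12` keeps the shared core and changes one group, with 1,3-benzoxazol-2-yl entering on a saturated chain carbon bound to an oxygen on an aromatic ring: a group of 9 heavy atoms (7 carbon, 1 nitrogen, 1 oxygen; one five-membered aromatic ring with 2 hetero atoms, one six-membered aromatic ring of carbon only) in place of a group of 10 heavy atoms (8 carbon, 2 nitrogen; 2 six-membered aromatic rings with 1 hetero atom each), on a saturated chain carbon bound to an oxygen on an aromatic ring. For the measured compounds named here, the one measured step that bears on this change is a step that the two limits leave unreadable from compound 1 to compound 2, which concerns the same place and has no readable size. Going by the values given here, both compounds sit at the same ceiling, as the limit of > 3000 nM in this assay, at which 2 of the 2 values shown sit, shows, and no measured compound in this assay has yet given a number. The data therefore offer no ground for expecting a change beyond the scatter, in either direction. The expected step is a number no higher from compound 2 to compound 3 (the limit leaves the size open), an estimate that assumes compound 3 stays close to that ceiling. For compound 3 the estimated value is 3000 nM, with an expected range from 1000 nM to 10000 nM.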

Compound 3, half-maximal inhibitory concentration: 2500 nM
Estimate against measurement, compound 3: 1.2-fold (0.08 log units) above, and the stated range covers the measured number.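

For the compounds shown here, compound 3 is the first compound in this assay to give a number and not a limit, so this place, a saturated chain carbon bound to an oxygen on an aromatic ring, can carry a group, here 1,3-benzoxazol-2-yl, that yields a readable value. The data give an at least 1.2-fold lower number from compound 2 to compound 3 (0.07 log units; that floor lies within the scatter), and likewise an at least 1.2-fold lower number from compound 1 to compound 3 (0.07 log units; that floor lies within the scatter); each of these is a floor and not a size, so the change from either six-membered pair of rings to the benzoxazole may be small or large. The number for compound 3 also stands alone, and the series still rests largely on limits: the limit of > 3000 nM in this assay, at which 2 of the 3 values shown sit.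

The compounds shown leave open how far compound 1 and compound 2 really lie from compound 3, and whether the five-membered aromatic ring or its oxygen goes with the readable value. A group such as 1,3-benzothiazol-2-yl, with sulfur in the ring in place of that oxygen, would bear on this question at the same place on the shared core.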